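This account rests on a few compounds, and the source may have more. Where it says the series, first, only, none or still open, it means among the compounds named here.

The series shares one core, carried in compound 1 `O=C(O)c1ccccc1-c1ccc(CCc2ncc(CC3CCC3)[nH]2)cc1`, compound 2 `O=C(O)c1ccccc1-c1ccc(CCc2ncc(C3CCCCC3)[nH]2)cc1` and compound 3 `O=C(O)c1ccccc1-c1ccc(CCc2ncc(CC3CCCC3)[nH]2)cc1`, and differs only in the group on the five-membered heteroaromatic ring. In an in vitro functional assay on cells for agonist activity at Bombesin receptor subtype-3 (Mus musculus), read by luminescence and calcium flux (on this read-out lower numbers stand for an effect already at smaller amounts and higher numbers for an effect only at larger amounts of compound), compound 1 gives 7.1 nM, compound 2 gives 14.7 nM and compound 3 gives 7.9 nM. Compound 3 thus has the second highest of the three numbers, though it sits within the scatter of both neighbours: a 1.1-fold higher number from compound 1 to compound 3 (0.05 log units; within the scatter) and a 1.9-fold lower number from compound 2 to compound 3 (0.27 log units; within the scatter). Going by the values given here, only the step of a 2.1-fold higher number from compound 1 to compound 2 (0.32 log units; beyond the scatter) reaches beyond the scatter, and then modestly.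

Compound 4 `O=C(O)c1ccccc1-c1ccc(CCc2ncc(Cc3ccccc3F)[nH]2)cc1` takes the step (2-fluorophenyl in place of cyclopentyl on a saturated chain carbon bound to an aromatic carbon). No measured pair bears on this change directly: the three known steps all swap one saturated carbon ring for another, and each of them, as shown in this assay, is small. Since every move within this set stays near the value of compound 3, a small step is expected in this assay for compound 4 as well, a 1.3-fold higher number from compound 3 to compound 4 (0.10 log units; within the scatter), with no firm direction. On that basis compound 4 is expected to give about 10 nM in this assay, estimated to lie between 3 nM and 35 nM.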

Compound 4, half-maximal effective concentration: 9.5 nM
Beside the measured number, compound 4's estimate is 1.1-fold (0.02 log units) above it; low and high end bracket the measured number.
By their numbers in this assay, from the lowest: compounds 1, 3, 4 and 2 (each within the scatter of the next, the first and the last beyond it).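

In this assay, going by these compounds alone, the position takes 2-fluorophenyl in place of cyclopentyl on a saturated chain carbon bound to an aromatic carbon with no step beyond the scatter (a 1.2-fold higher number from compound 3 to compound 4 (0.08 log units; within the scatter)), so an aromatic ring of carbon carrying fluorine is tolerated here, whereas the earlier compounds held only saturated carbon rings. The comparisons with the other two compounds read the same way (a 1.3-fold higher number from compound 1 to compound 4 (0.13 log units; within the scatter) and a 1.5-fold lower number from compound 2 to compound 4 (0.19 log units; within the scatter)), which leaves compound 4 inseparable from all three and the step between compound 1 and compound 2 still the only one beyond the scatter. Nothing given here explains why the exchange of a saturated ring for an aromatic one leaves the number within the scatter.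

As far as these compounds go, what remains open is whether the fluorine contributes anything, as a plain benzyl group would show, and whether the aromatic ring stays tolerated on a longer chain than the single carbon present here. Also open is how the position would respond to a group of another kind, such as an amine or a carboxylic acid, since every group shown so far is built of carbon apart from the one fluorine.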